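Tetrazole in place of the bicyclic heteroaryl on the ketone chain

A few compounds are considered here, and "the series" means these few. Any claim that something is new, unique, unknown or untested is made for them only; others in the source may bear on it.

The series shares a core with an octyl-substituted aryl ether linked to a ketone, with a nitrogen heteroaryl on the saturated chain carbon bound to the carbonyl carbon. Compound 1 `CCCCCCCCc1ccc(OCC(=O)Cn2ncc3ccccc32)cc1` gives 2300 nM in an assay on microsomes from brain for inhibition of Fatty-acid amide hydrolase 1 (Rattus norvegicus), read by fluorescence and HPLC, with a stated time of 60 min; a higher number here means a weaker inhibitor, a lower number a stronger inhibitor; compound 2 `CCCCCCCCc1ccc(OCC(=O)Cn2ncc3cccnc32)cc1` gives 1600 nM; compound 3 `CCCCCCCCc1ccc(OCC(=O)Cn2nnc3ncccc32)cc1` gives 49 nM. Compound 3 stands lowest of the three, with a 47-fold lower number from compound 1 to compound 3 (1.67 log units; beyond the scatter) and a 33-fold lower number from compound 2 to compound 3 (1.51 log units; beyond the scatter), while a 1.4-fold lower number from compound 1 to compound 2 (0.16 log units; within the scatter) is within the scatter.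

Compound 4 `CCCCCCCCc1ccc(OCC(=O)Cn2cnnn2)cc1` differs from compound 3 in one place: a group of 5 heavy atoms (1 carbon, 4 nitrogen; one five-membered aromatic ring with 4 hetero atoms) in place of a group of 9 heavy atoms (5 carbon, 4 nitrogen; one five-membered aromatic ring with 3 hetero atoms, one six-membered aromatic ring with 1 hetero atom), on a saturated chain carbon bound to a carbonyl carbon. For the measured compounds named here, none of the measured steps covers removal of the six-membered ring; the steps from compound 1 and compound 2 to compound 3 only show that the triazole-containing bicyclic group carried a large gain. From the compounds shown here alone, whether that gain survives the loss of the six-membered ring is untested, so the step from compound 3 to compound 4 is expected to run toward a higher number in this assay, of uncertain size and plausibly large.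

Compound 4 is estimated at 700 nM, with a range from 120 nM to 4000 nM, which corresponds to an expected step of a 14-fold higher number from compound 3 to compound 4 (1.15 log units; beyond the scatter).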

Compound 4, half-maximal inhibitory concentration: 39 nM
The estimate for compound 4 lay 18-fold (1.25 log units) above the measured number; measured number below the stated range.
By their numbers in this assay, from the lowest: compounds 4 and 3 (each within the scatter of the next); then compounds 2 and 1 (each within the scatter of the next).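

In this assay, the six-membered ring is not required at this place, on a saturated chain carbon bound to a carbonyl carbon: 1H-tetrazol-1-yl alone stands level with the larger group it replaces, with a 1.3-fold lower number from compound 3 to compound 4 (0.10 log units; within the scatter), and still keeps the large gap to the two other bicyclic groups, with a 41-fold lower number from compound 2 to compound 4 (1.61 log units; beyond the scatter) and a 59-fold lower number from compound 1 to compound 4 (1.77 log units; beyond the scatter). Across these four compounds, the low numbers now go with a five-membered aromatic ring with 3 or 4 hetero atoms, with or without the fused six-membered ring, and the high numbers with a five-membered aromatic ring with 2 hetero atoms, with no compound here going against this. Nothing at hand gives a reason for this behaviour.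

The compounds shown leave open whether the tetrazole tolerates a substituent on its ring carbon, such as a methyl or a phenyl, and whether 2H-tetrazol-2-yl or a monocyclic 1,2,3-triazole would give a number like that of compound 4. From the compounds shown here alone, it also remains open whether this result holds with a shorter or longer chain in place of the octyl group.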